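The source may hold more compounds than are shown below. What is called first, only, known or untested is meant among the compounds shown, and "the series" means these compounds.

Measured so far:
Compound 1, `Cn1ncc2cc(NC(=O)NCc3cc(C(F)(F)F)nn3-c3cccc(Cl)c3)ccc21`: in an assay on CHO-K1 cells for antagonist activity at transient receptor potential cation channel subfamily V member 1 (Homo sapiens), read by FLIPR and calcium flux, with a stated time of 6 min (a higher number here means a weaker inhibitor, a lower number a stronger inhibitor), compound 1 gives 61 nM.
Compound 2, `O=C(NCc1cc(C(F)(F)F)nn1-c1cccc(Cl)c1)Nc1cccc2[nH]ncc12`: compound 2 gives 0.9 nM.
Compound 3, `CC(C)(C)c1cc(CNC(=O)Nc2cccc3[nH]ncc23)n(-c2cccc(Cl)c2)n1`: compound 3 gives 0.6 nM.

Compound 3 has the lowest of the three numbers, but its separation from compound 2 is only a 1.5-fold lower number from compound 2 to compound 3 (0.18 log units; within the scatter), which lies within the scatter, so the two cannot be ordered. Compound 1 stands well apart from both, the move being a 68-fold lower number from compound 1 to compound 2 (1.83 log units; beyond the scatter); that step replaced the core of compound 1 with that of compound 2, changing both the point of attachment and the methyl on the ring nitrogen at once.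

Compound 4, `CC(=O)n1ncc2c(NC(=O)NCc3cc(C(C)(C)C)nn3-c3cccc(Cl)c3)cccc21`, differs from compound 3 by acetyl in place of hydrogen on an aromatic nitrogen. Within the data shown here, no measured step isolates a change at that ring nitrogen: the step from compound 1 to compound 2 mixed it with a change of attachment, and the step from compound 2 to compound 3 concerns the pyrazole substituent. The precedent is therefore indirect, and a single such step gives no secure direction. A moderate rise in the number is expected, a 5.0-fold higher number from compound 3 to compound 4 (0.70 log units; beyond the scatter), with a broad range reflecting the lack of a clean comparison. Compound 4 is estimated at 3 nM in this assay, between 0.6 nM and 20 nM.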

Compound 4, inhibition constant: 29.5 nM
Compound 4: middle estimate off by 9.8-fold (0.99 log units), on the low side; the whole stated range lies below it.
By their numbers in this assay, from the lowest: compounds 3 and 2 (each within the scatter of the next); then compound 4; then compound 1.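

In this assay, among these compounds, the exchange of hydrogen for acetyl on the aromatic nitrogen gives a 49-fold higher number from compound 3 to compound 4 (1.69 log units; beyond the scatter), and this is the first step that reads this nitrogen alone, with the attachment of the urea and the pyrazole substituent held constant. Substitution at this position is therefore not neutral, whereas the exchange of trifluoromethyl for tert-butyl elsewhere in the molecule, a 1.5-fold lower number from compound 2 to compound 3 (0.18 log units; within the scatter), stays within the scatter. No measurement at hand accounts for the size of the new step.

Still open, as far as these compounds go, is whether the rise belongs to acetyl itself or would follow any group that replaces this hydrogen, a question that an ethyl or a longer acyl chain such as propanoyl on the same nitrogen of compound 3 would help to answer. Also open, from the compounds shown here alone, are whether a carbonyl-free group carrying an amine would hold the number nearer that of compound 3, and whether acetyl at this nitrogen gives a step of similar size when trifluoromethyl stands in place of tert-butyl, as in compound 2.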